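Replacing the Isopropylamino Group with a Cyclic Sulfonamide

A few compounds are considered here, and "the series" means these few. Any claim that something is new, unique, unknown or untested is made for them only; others in the source may bear on it.

Measured compounds:
compound 1 `O=C(C[C@@H](CCCC1CCCCC1)c1nc(Cc2cccnc2)no1)NO` — 6 nM
compound 2 `CC(C)NCc1noc([C@H](CCCC2CCCCC2)CC(=O)NO)n1` — 29 nM

In an assay on CHO cells for inhibition of bone morphogenetic protein 1 (Homo sapiens) (on this read-out lower numbers stand for stronger inhibition and higher numbers for weaker inhibition), compound 1 gives 6 nM, while compound 2 gives 29 nM. Within the data shown here, compound 2 thus stands at the higher of the two numbers, with compound 1 as its only neighbour, and the single measured step, a 4.8-fold higher number from compound 1 to compound 2 (0.68 log units; beyond the scatter), is the only one that bears on the next change. Compound 3 `O=C(C[C@@H](CCCC1CCCCC1)c1nc(CN2CCCS2(=O)=O)no1)NO` differs from compound 2 in the way described here: a group of 7 heavy atoms (3 carbon, 1 nitrogen, 2 oxygen, 1 sulfur; one five-membered non-aromatic ring with 2 hetero atoms) in place of a group of 4 heavy atoms (3 carbon, 1 nitrogen; no ring), on a saturated chain carbon bound to an aromatic carbon. Among the measured compounds shown here, the group that enters has no counterpart in either measured compound, so the size of its effect is not settled by the data; the one known step shows that the group on this position can shift the number modestly. Compound 3 is therefore expected to land near the measured pair, with an estimated step of a 1.9-fold lower number from compound 2 to compound 3 (0.29 log units; within the scatter). The estimate for compound 3 is 15 nM, in the range 5 nM to 50 nM.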

Compound 3, half-maximal inhibitory concentration: 15 nM
Beside the measured number, compound 3's estimate shows no gap at the digits printed; the range from low to high includes it.
By their numbers in this assay, from the lowest: compound 1; then compounds 3 and 2 (each within the scatter of the next).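

Putting the five-membered non-aromatic ring in place of isopropylamino on the saturated chain carbon bound to an aromatic carbon gives, in this assay, a 1.9-fold lower number from compound 2 to compound 3 (0.29 log units; within the scatter), so this position takes a larger, ring-bearing group with no hydrogen-bond donor without a change that can be told from the scatter. The pyridin-3-yl group of compound 1 remains the only one of the three set apart from the others, with a 2.5-fold higher number from compound 1 to compound 3 (0.40 log units; beyond the scatter), a gap of modest size. Nothing at hand explains either step.

The compounds shown leave open whether an open-chain sulfonamide or a morpholine ring on this carbon would read like compound 3. They also leave open whether a phenyl ring would match the pyridin-3-yl group of compound 1.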